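Swapping the anilino nitro for a methyl in a pyrimidine series

The compounds below may be only part of what the source reports. "The series", "measured", "known", "first", "only" and "open" are said of these compounds alone.

Compound 1, `N#Cc1c(Nc2cccc([N+](=O)[O-])c2)nc(SCc2cn(Cc3ccccc3Cl)nn2)nc1-c1ccccc1`, gives 43100 nM in a functional assay on MGC-803 cells (Homo sapiens) for inhibition, read by MTT assay, with a stated time of 72 h; on this read-out lower numbers stand for stronger inhibition and higher numbers for weaker inhibition. Compound 2, `Cc1ccc(Cn2cc(CSc3nc(Nc4ccccc4F)c(C#N)c(-c4ccccc4)n3)nn2)cc1`, gives 22900 nM in this assay.

Only these two numbers are known, and they do not separate: compound 1 and compound 2 lie within the usual scatter of each other, so neither can be called the more or less potent of the pair. Both sit in a region of the read-out that points to modest inhibition.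

Compound 3, `Cc1ccc(Nc2nc(SCc3cn(Cc4ccccc4Cl)nn3)nc(-c3ccccc3)c2C#N)cc1`, has not been measured in this assay. Against compound 1 the change is 4-methylphenyl in place of 3-nitrophenyl on a nitrogen on an aromatic ring. Going by the values given here, no measured pair in this set isolates that change, and compound 2 differs from compound 3 in more than one place, so its value is only a general reference. On these grounds the step from compound 1 to compound 3 is expected to stay small, with no clear direction beyond the scatter: the estimated step is a 1.4-fold lower number from compound 1 to compound 3 (0.16 log units; within the scatter). Compound 3 is accordingly expected to give about 30000 nM in this assay, within a range from 10000 nM to 90000 nM.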

Compound 3, half-maximal inhibitory concentration: 7190 nM
For compound 3 the middle estimate is 4.2-fold (0.62 log units) above the measured one; measured number outside the range, below it.
By their numbers in this assay, from the lowest: compound 3; then compounds 2 and 1 (each within the scatter of the next).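

Going by these compounds alone, the change of 3-nitrophenyl to 4-methylphenyl on a nitrogen on an aromatic ring gives the first step in this set between compounds that differ in one place, and it shows that this position can move the number in this assay. The step is a 6.0-fold lower number from compound 1 to compound 3 (0.78 log units; beyond the scatter) and so lies beyond the scatter, although it is modest, whereas the earlier pair differed in more than one place and stayed within the scatter of each other. Nothing measured here accounts for the lower number, so the step stands only as an observation for this single pair.

The swap replaces the nitro group with a methyl group and also changes the number in the group's name from 3 to 4, so the compounds shown cannot tell whether the step follows from losing the nitro group, gaining the methyl group or the new location on the ring. On these data alone, it also remains open how this nitrogen substituent would read out as a plain phenyl, or as a phenyl carrying a methoxy group, an amine or a carboxylic acid.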